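A Different Aryl Group on the Sulfonyl Sulfur

The source may report more compounds than this note shows. Statements on the series, on what has been measured and on what is new or still open speak of the compounds shown alone.

Of the compounds shown here, three built on one shared core have been measured in an assay on cells for inhibition of HSP60/HSP10 (Homo sapiens), with a stated time of 60 min; a higher number here means a weaker inhibitor, a lower number a stronger inhibitor. Compound 1 `O=S(=O)(Nc1ccc(-c2nc3ccccc3o2)cc1)c1cccc(F)c1` gives 71000 nM. Compound 2 `O=S(=O)(Nc1ccc(-c2nc3ccccc3o2)cc1)c1ccccc1F` reaches only the limit of > 100000 nM, so no number is known for it. Compound 3 `O=S(=O)(Nc1ccc(-c2nc3cc(NS(=O)(=O)c4ccccc4F)ccc3o2)cc1)c1ccccc1F`, which carries a second sulfonamide on the core, gives 57000 nM. Across these, an at least 1.4-fold higher number from compound 1 to compound 2 (0.14 log units; that floor lies within the scatter), and an at least 1.7-fold lower number from compound 2 to compound 3 (0.24 log units; that floor lies within the scatter); both floors sit within the usual scatter. As the limit of > 100000 nM in this assay, at which 1 of the 3 values shown sits, records, compound 2 stands only as a limit, not as a figure.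

Compound 4 `COc1ccc(Cl)cc1S(=O)(=O)Nc1ccc(-c2nc3ccccc3o2)cc1` is not yet measured. It differs from compound 2 in one place: 5-chloro-2-methoxyphenyl in place of 2-fluorophenyl on a sulfonyl sulfur. The measured steps that bear on this are the two above: one changes the aryl group on the sulfonyl sulfur, the other adds a second sulfonamide, and neither moved beyond the scatter. Nothing in these data points to a large shift in either direction, and a limit is a real possibility again. Compound 4 is therefore expected to give about 100000 nM in this assay, within 40000 nM to 250000 nM. The step of a number no higher from compound 2 to compound 4 (the limit leaves the size open) is expected to stay within the scatter.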

Compound 4, half-maximal inhibitory concentration: > 100000 nM
Compound 4: no number, only a limit; the forecaster's own chance of this, stated with the estimate: 50%; the middle value sits exactly at the limit.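

With 5-chloro-2-methoxyphenyl on the sulfonyl sulfur, compound 4 also stays a limit and not a number in this assay, as compound 2 does, so the step between these two compounds cannot be read. Among these compounds, the only readable comparison for this new group starts from the 3-fluorophenyl group, and swapping that group for 5-chloro-2-methoxyphenyl gives an at least 1.4-fold higher number from compound 1 to compound 4 (0.14 log units; that floor lies within the scatter). Among the compounds with a single sulfonamide, two different aryl groups on the sulfonyl sulfur now end at the same limit, and only the 3-fluorophenyl group of compound 1 gives a number: the limit of > 100000 nM in this assay, at which 2 of the 4 values shown sit.

Going by these compounds, it remains open whether an amine or a carboxylic acid on this aryl ring, or a plain alkyl chain in place of the ring, would give a readable number, and how far such a change would move it. On these data alone, it is equally open whether the second sulfonamide carried by compound 3 would give a number when paired with 5-chloro-2-methoxyphenyl.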